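This account rests on a few compounds, and the source may have more. Where it says the series, first, only, none or still open, it means among the compounds named here.

Measured so far in an ADME assay on microsomes from liver (Homo sapiens) for metabolic stability, tested at 2.5 uM; a lower number here means slower removal, a higher number faster removal of the compound:
compound 1, `Fc1cc(Cl)ccc1-c1ccc(Cn2nnc3ccccc32)cn1`: 0.01 mL/min/g
compound 2, `Fc1ccc2nnn(Cc3ccc(-c4ccc(Cl)cc4F)nc3)c2c1`: 0.1 mL/min/g
compound 3, `Brc1cccc2c1nnn2Cc1ccccc1`: 4.7 mL/min/g

Compound 1 and compound 2 share one core and differ in a single place: fluoro in place of hydrogen on an aromatic carbon. That change brought a 10-fold higher number from compound 1 to compound 2 (1.00 log units; beyond the scatter). Compound 3 has a different core, and how its core differs from that of compound 1 is not broken down here. Its number stands highest of the three, beyond the scatter from both others.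

Compound 4, `Fc1ccc(Cn2nnc3c(Br)cccc32)cc1`, has not yet been measured. It differs from compound 3 in one place: fluoro in place of hydrogen on an aromatic carbon. Among the measured compounds shown here, this is the same kind of change as the one from compound 1 to compound 2, but not the same: there the fluoro sits on a ring that is part of a fused or bridged system of two rings, meta to a fused ring and para to a fused ring, while here it sits on a six-membered aromatic ring of carbon only, para to a large group. For compound 4 a step of a 1.5-fold higher number from compound 3 to compound 4 (0.17 log units; within the scatter) is expected. That expectation rests on a 10-fold higher number from compound 1 to compound 2 (1.00 log units; beyond the scatter), tempered by the surroundings of the change not being the same and by compound 3 already standing highest. Compound 4 is therefore expected near 7 mL/min/g, with a likely range from 2.5 mL/min/g to 20 mL/min/g.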

Compound 4, intrinsic clearance in a liver preparation (reported as CLH), per the amount of preparation that the assay uses: 1.2 mL/min/g
Estimate against measurement, compound 4: 5.8-fold (0.77 log units) above; measured number below the stated range.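

In this assay, fluoro in place of hydrogen on an aromatic carbon gave a 3.9-fold lower number from compound 3 to compound 4 (0.59 log units; beyond the scatter), so on this core the number moved the opposite way from the earlier pair. Set side by side, the two results differ by more than repeat measurements would explain: the same change on two cores in this assay, a 10-fold higher number (1.00 log units; beyond the scatter) from compound 1 to compound 2 and a 3.9-fold lower number (0.59 log units; beyond the scatter) from compound 3 to compound 4, 39-fold (1.59 log units) apart, beyond the scatter of two such steps This shows that the effect of this change cannot simply be carried from one core to another in this series, but with only two pairs, which also place the fluoro on different kinds of ring, it does not show whether the core or the place of the fluoro decides the direction.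

The compounds shown leave open whether fluoro on the fused system of two rings in compound 3 would move the number the way it did in compound 2. Also open, on these data alone, is whether a methoxy group or an amine in the place the fluoro takes in compound 4 would lower the number too.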